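Ring substituent on the amide benzyl and cytotoxicity

The compounds below may be only part of what the source reports. "The series", "measured", "known", "first", "only" and "open" are said of these compounds alone.

Compound 3 `COC(=O)C[C@H](NC(=O)OC(C)(C)C)C(=O)N(Cc1ccc(C)cc1)C1(C(=O)NCc2ccccc2)CCN(Cc2ccccc2)CC1` is known in an ADME assay on MDCK cells (Canis lupus familiaris) for cytotoxicity, read by microscopy, with a stated time of 72 h (on this read-out lower numbers stand for higher toxicity in this test and higher numbers for lower toxicity in this test), only as a limit, > 100000 nM. Compound 1 `COC(=O)C[C@H](NC(=O)OC(C)(C)C)C(=O)N(Cc1ccccc1)C1(C(=O)NCc2ccccc2)CCN(Cc2ccccc2)CC1` also sits at a limit in this assay, > 100000 nM. Compound 2 `CCC(C)N(C(=O)[C@H](CC(=O)OC)NC(=O)OC(C)(C)C)C1(C(=O)NCc2ccccc2)CCN(Cc2ccccc2)CC1` gives a number in this assay, 84000 nM. Two of the three values sit at the same limit (the limit of > 100000 nM in this assay, at which 2 of the 3 values shown sit), so the measured steps are small or unreadable: an at least 1.1-fold lower number from compound 1 to compound 2 (0.07 log units; that floor lies within the scatter), an at least 1.1-fold higher number from compound 2 to compound 3 (0.07 log units; that floor lies within the scatter) and a step that the two limits leave unreadable from compound 1 to compound 3.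

Compound 4 `COC(=O)C[C@H](NC(=O)OC(C)(C)C)C(=O)N(Cc1ccccc1F)C1(C(=O)NCc2ccccc2)CCN(Cc2ccccc2)CC1` differs from compound 3 by 2-fluorophenyl in place of 4-methylphenyl on a saturated chain carbon bound to an amide-type nitrogen. Going by the values given here, the only measured change on that aromatic ring, methyl in place of hydrogen, left no readable step, and the exchange of the whole group on the amide-type nitrogen stayed within scatter. No step beyond the scatter is therefore expected, a number no higher from compound 3 to compound 4 (the limit leaves the size open). Compound 4 is estimated at 100000 nM, with a range of 40000 nM to 250000 nM, most likely reported as a limit again.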

Compound 4, minimum cytotoxic concentration: 20000 nM
Compound 4: middle estimate off by 5.0-fold (0.70 log units), on the high side, and the stated range ends above it.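

In this assay, the aromatic ring on the amide benzyl gives the first steps clearly beyond the scatter: fluoro in place of hydrogen gives an at least 5.0-fold lower number from compound 1 to compound 4 (0.69 log units; beyond the scatter) and 2-fluorobenzyl in place of 4-methylbenzyl gives an at least 5.0-fold lower number from compound 3 to compound 4 (0.69 log units; beyond the scatter). Against sec-butyl, 2-fluorobenzyl gives a 4.2-fold lower number from compound 2 to compound 4 (0.62 log units; beyond the scatter), so the group on the amide-type nitrogen now has a readable effect on this read-out. The two floors start from a limit, so their full size cannot be read: the limit of > 100000 nM in this assay, at which 2 of the 4 values shown sit.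

Going by these compounds, whether 4-fluorobenzyl or 2-chlorobenzyl would give a similar step remains open. So does the effect of a carboxylic acid in place of the methyl ester.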